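Chain hydroxamate replaces aryl hydroxamate in a thiazole series

A few compounds are considered here, and "the series" means these few. Any claim that something is new, unique, unknown or untested is made for them only; others in the source may bear on it.

Of the compounds shown here, three sharing the core seen in compound 1 have been measured. In a functional assay on HCT-116 cells (Homo sapiens) for inhibition, read by MTT assay, with a stated time of 72 h (a lower number here means a stronger inhibitor, a higher number a weaker inhibitor), compound 1 `O=C(NO)c1ccc(CN(Cc2ccc(F)cc2)c2ncc(C(=O)NCCCn3ccnc3)s2)cc1` gives 99000 nM, the highest of the three numbers. Going by the values given here, compound 2 `CC(C)CCN(CCCCCCC(=O)NO)c1ncc(C(=O)NCc2cccnc2)s1` gives 12000 nM and compound 3 `CC(C)CCN(CCCCCCC(=O)NO)c1ncc(C(=O)NCCCn2ccnc2)s1` gives 30000 nM; between those two the only measured step is a 2.5-fold higher number from compound 2 to compound 3 (0.40 log units; beyond the scatter). Compound 1 is thus set apart from compound 3 and, further still, from compound 2, both gaps standing beyond the scatter.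

Compound 4 `O=C(CCCCCN(Cc1ccc(F)cc1)c1ncc(C(=O)NCCCn2ccnc2)s1)NO` has not yet been measured in this assay. It differs from compound 1 in one place: 4-(hydroxycarbamoyl)butyl in place of 4-(hydroxycarbamoyl)phenyl on a saturated chain carbon bound to a nitrogen on an aromatic ring. Among the compounds with values here, no measured step bears directly on this change, since compounds 2 and 3 carry a chain hydroxamate but also differ from compound 1 in the group on the ring nitrogen. What the numbers show is that both chain-hydroxamate compounds sit well below compound 1, and compound 3 shares the imidazolylpropyl amide with compound 4. A move toward lower numbers, of the order of the gap to compound 3, is therefore expected, as a 2.8-fold lower number from compound 1 to compound 4 (0.45 log units; beyond the scatter). Compound 4 is estimated to give 35000 nM, in the range 12000 nM to 100000 nM.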

Compound 4, half-maximal inhibitory concentration: 19000 nM
For compound 4 the middle estimate is 1.8-fold (0.27 log units) above the measured one, and the stated range covers the measured number.
By their numbers in this assay, from the lowest: compounds 2, 4 and 3 (each within the scatter of the next, the first and the last beyond it); then compound 1.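

In this assay, going by these compounds alone, the change gives a 5.2-fold lower number from compound 1 to compound 4 (0.72 log units; beyond the scatter), which is the first reading of this position with everything else in the molecule held fixed. On a saturated chain carbon bound to a nitrogen on an aromatic ring, the six-membered aromatic ring of 4-(hydroxycarbamoyl)phenyl can therefore give way to the ring-free 4-(hydroxycarbamoyl)butyl without any loss in this read-out, and the number falls beyond the scatter while the hydroxycarbamoyl end and the counts of hydrogen-bond donors and acceptors stay as they were. Nothing on hand accounts for the size or direction of this step.

Within the data shown here, the single step cannot separate the removal of the aromatic ring from the change in the span of the linker, and it gives no reading of a longer chain or a shorter chain at this position, nor of a carboxylic acid in place of the hydroxycarbamoyl group. It also leaves open whether the same exchange would lower the number with the pyridin-3-yl amide of compound 2 , or with an amine on the chain.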